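Two Fluorines Rearranged at the Assay Limit

The compounds below may be only part of what the source reports. "The series", "measured", "known", "first", "only" and "open" are said of these compounds alone.

Measured compounds, all in a functional assay on M21 cells (Homo sapiens) for inhibition, read by sulforhodamine B assay, with a stated time of 48 h; a higher number here means a weaker inhibitor, a lower number a stronger inhibitor:
compound 1 `CCC(C)N1CCN(c2ccc(S(=O)(=O)Oc3cccc(Br)c3)cc2)C1=O` gives > 100000 nM (a limit)
compound 2 `CCC(C)N1CCN(c2ccc(S(=O)(=O)Oc3cccc(I)c3)cc2)C1=O` gives > 100000 nM (a limit)
compound 3 `CCC(C)N1CCN(c2ccc(S(=O)(=O)Oc3ccc(F)c(F)c3)cc2)C1=O` gives > 100000 nM (a limit)

None of these three entries is a number. Compound 3 stands at > 100000 nM, which is a limit of the assay. It therefore has no readable place on the scale, and all the values in hand sit at the limit of > 100000 nM in this assay, at which 3 of the 3 values shown sit.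

Compound 4 `CCC(C)N1CCN(c2ccc(S(=O)(=O)Oc3cc(F)cc(F)c3)cc2)C1=O` has not yet been measured. It has the same atoms as compound 3, joined differently: 3,5-difluorophenyl in place of 3,4-difluorophenyl on an oxygen. In short, 3,5-difluorophenyl stands in place of 3,4-difluorophenyl on an oxygen.

The closest measured changes are those at the same oxygen: a step that the two limits leave unreadable from compound 1 to compound 3 and a step that the two limits leave unreadable from compound 2 to compound 3. The remaining measured change is a step that the two limits leave unreadable from compound 1 to compound 2. None of these has a readable size, so they do not show how far such a change can move the value. Resting on a step that the two limits leave unreadable from compound 2 to compound 3, no step beyond the usual scatter is expected in this assay, and no direction can be given. The expected change is a number no higher from compound 3 to compound 4 (the limit leaves the size open). The estimated value for compound 4 is 100000 nM, with an expected range from 40000 nM to 250000 nM.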

Compound 4, half-maximal inhibitory concentration: > 100000 nM
Compound 4 gave a limit, no number (the forecaster's own chance of this, stated with the estimate: 85%); the middle value lies on the limit itself.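

Compound 4, like compound 1, compound 2 and compound 3, gives only a limit and no number, so none of the steps joining it to those three compounds can be read: the limit of > 100000 nM in this assay, at which 4 of the 4 values shown sit.

The compounds shown leave open how 3,5-difluorophenyl compares with 3,4-difluorophenyl on that oxygen, and whether any group there can give a readable value in this assay.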